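This account rests on a few compounds, and the source may have more. Where it says the series, first, only, none or still open, it means among the compounds named here.

Compound 1 `O=C(CN1CCN(c2cc3c(cc2F)c(=O)c(C(=O)O)cn3C2CC2)CC1)Nc1ccc(C(=O)/C=C/c2cccc(Cl)c2)cc1`: 29.7 ug/mL
Compound 2 `O=C(CN1CCN(c2cc3c(cc2F)c(=O)c(C(=O)O)cn3C2CC2)CC1)Nc1ccc(C(=O)/C=C/c2ccc(Cl)cc2)cc1`: 2.23 ug/mL

Going by the values given here, in a physicochemical assay for solubility, at pH 7.8 (a higher number here means a more soluble compound, a lower number a less soluble compound), compound 2 gives the lower of the two numbers; the one measured step, a 13-fold lower number from compound 1 to compound 2 (1.12 log units; beyond the scatter), separates it from compound 1 and is large. Compound 3 `COc1ccc(/C=C/C(=O)c2ccc(NC(=O)CN3CCN(c4cc5c(cc4F)c(=O)c(C(=O)O)cn5C4CC4)CC3)cc2)cc1` differs from compound 2 by methoxy in place of chloro on an aromatic carbon. Among the compounds with values here, no measured step bears on this change; the only step known concerns the place of the chloro group, not its replacement, so nothing in the data points to a direction. Compound 3 is therefore expected to stay near compound 2, with an estimated step of a 1.8-fold higher number from compound 2 to compound 3 (0.25 log units; within the scatter). The expected value of compound 3 in this assay is 4 ug/mL, estimated to lie between 1.5 ug/mL and 12 ug/mL.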

Compound 3, solubility: 2.42 ug/mL
The estimate for compound 3 lay 1.7-fold (0.22 log units) above the measured number, within the range that was stated.
By their numbers in this assay, from the lowest: compounds 2 and 3 (each within the scatter of the next); then compound 1.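

With methoxy in place of chloro on this aromatic carbon, para to a large group, this assay shows a 1.1-fold higher number from compound 2 to compound 3 (0.04 log units; within the scatter), so here the two groups cannot be told apart. The step of a 12-fold lower number from compound 1 to compound 3 (1.09 log units; beyond the scatter) is large, which shows that the low number is not confined to the 4-chlorophenyl compound. No measurement given here explains either result. Still open, as far as these compounds go, is whether an amine or a carboxylic acid on this same carbon would stay with compound 2 and compound 3 or move toward compound 1.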